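Dropping both methyls from the biaryl of compound 1

The compounds below may be only part of what the source reports. "The series", "measured", "known", "first", "only" and "open" are said of these compounds alone.

Compound 1 `Cc1cccc(C)c1-c1cccc(COc2ccc(S(=O)(=O)CC(=O)O)cc2)c1` gives the lowest of three numbers in a functional assay on CHO cells for agonist activity at Free fatty acid receptor 1 (Homo sapiens), read by FLIPR and calcium flux (on this read-out lower numbers stand for an effect already at smaller amounts and higher numbers for an effect only at larger amounts of compound), with 66.1 nM. Compound 2 `Cc1cc(OCC(C)C)cc(C)c1-c1cccc(COc2ccc(S(=O)(=O)CC(=O)O)cc2)c1` gives 95.5 nM and compound 3 `Cc1cc(OCC2CC2)cc(C)c1-c1cccc(COc2ccc(S(=O)(=O)CC(=O)O)cc2)c1` gives 79.4 nM; the steps of a 1.4-fold higher number from compound 1 to compound 2 (0.16 log units; within the scatter) and a 1.2-fold higher number from compound 1 to compound 3 (0.08 log units; within the scatter) both stay within the scatter, so the three compounds cannot be ranked. Compound 4 `O=C(O)CS(=O)(=O)c1ccc(OCc2cccc(-c3ccccc3)c2)cc1` arises from compound 1 by phenyl in place of 2,6-dimethylphenyl on an aromatic carbon. Among the measured compounds shown here, none of the measured steps touches this change; they all add groups elsewhere on the same ring, and every one stayed within the scatter. The expectation for compound 4 therefore rests on the change itself, and a higher number is expected, as the step of a 3.8-fold higher number from compound 1 to compound 4 (0.58 log units; beyond the scatter) is meant to show. Compound 4 is estimated at 250 nM in this assay, within a range from 80 nM to 800 nM.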

Compound 4, half-maximal effective concentration: 288 nM
Compound 4: the middle estimate sits 1.2-fold (0.06 log units) below what was measured; low and high end bracket the measured number.
By their numbers in this assay, from the lowest: compounds 1, 3 and 2 (each within the scatter of the next); then compound 4.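

Phenyl in place of 2,6-dimethylphenyl is the only change here that moves the number beyond the scatter: in this assay it gives a 4.4-fold higher number from compound 1 to compound 4 (0.64 log units; beyond the scatter), a modest step. The two methyls therefore matter to this read-out, whereas the groups added elsewhere on that ring in compound 2 and compound 3 left the number within the scatter of compound 1. Nothing given here explains this step.

On these data alone, whether a single methyl would be enough remains open. So does whether chlorine or methoxy could stand in for the two methyls.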